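A Methyl Group on the Chain of Compound 3

The source may hold more compounds than are shown below. What is called first, only, known or untested is meant among the compounds shown, and "the series" means these compounds.

In an ADME assay on S9 fraction from liver (Rattus norvegicus) for metabolic stability, read by LC-MS, using NADPH, with a stated time of 30 min (on this read-out higher numbers stand for a more stable compound and lower numbers for a less stable compound), compound 1 (`CCCCCCCCc1ccc(OCC(=O)Cn2nnc(-c3ccccc3)n2)cc1`) gives 33%. Compound 2 (`CCCCCCCCc1ccc(OCC(=O)Cn2nnc(-c3ccccn3)n2)cc1`) gives 30%, and the step is a number 3 percentage points lower from compound 1 to compound 2 (within the scatter). Compound 3 (`CCCCCCCCc1ccc(OCC(=O)Cn2nnc(-c3ccc(C(=O)O)cc3)n2)cc1`) gives < 5%, which is a limit of the assay and not a number. The two steps that lead to it are a number at least 28 percentage points lower from compound 1 to compound 3 (beyond the scatter) and a number at least 25 percentage points lower from compound 2 to compound 3 (beyond the scatter), so it stands clearly lowest of the three.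

Compound 4 (`CCCCCCCCc1ccc(OC(C)C(=O)Cn2nnc(-c3ccc(C(=O)O)cc3)n2)cc1`) differs from compound 3 in one place: methyl in place of hydrogen on a saturated chain carbon bound to a carbonyl carbon and an oxygen on an aromatic ring. All three measured steps were made on an aromatic carbon, so none of them gives a direct size for a change on this chain carbon. Compound 3 sits at the limit of < 5% in this assay, at which 1 of the 3 values shown sits, which leaves little room for a further fall in this assay. Any step that appears is therefore expected to be upward, and a small one, possibly none beyond the scatter. The estimated change is a number at least 5 percentage points higher from compound 3 to compound 4 (that floor lies within the scatter). For compound 4 the expected value is 10%, with an estimated range from 4% to 30%.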

Compound 4, percent of the compound remaining: 55%
The estimate for compound 4 lay 45 percentage points below the measured number; the whole stated range lies below it.
By their numbers in this assay, from the lowest: compounds 2 and 1 (each within the scatter of the next); then compound 4. At a limit, below all of these: compound 3.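

In this assay, methyl in place of hydrogen on a saturated chain carbon bound to a carbonyl carbon and an oxygen on an aromatic ring gives a number at least 50 percentage points higher from compound 3 to compound 4 (beyond the scatter) and so moves the read-out far more than its single carbon might suggest. Among these compounds, all the earlier steps were made on an aromatic carbon, so this is the first sign that this chain carbon matters in this read-out, and that a change there can lift a compound clear of the bottom of the assay. The step can be stated only as a bound, because compound 3 stands at a limit and not at a number: the limit of < 5% in this assay, at which 1 of the 4 values shown sits.

The compounds shown leave open whether the same methyl would also raise compound 1 or compound 2, which carry no carboxy group, and what lies behind the step cannot be told from these values. They also leave open whether an ethyl group, a longer chain or a fluorine atom on this chain carbon would give a step of similar size.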